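Extending the Chain of Compound 3 to a Phenoxy End

The compounds below may be only part of what the source reports. "The series", "measured", "known", "first", "only" and "open" are said of these compounds alone.

Compound 1 `O=c1cc(N2CCNCC2)oc2ccccc12` gives 56000 nM
Compound 2 `O=c1cc(N2CCNCC2)c2ccccc2o1` gives 49000 nM
Compound 3 `CCCOc1ccc2c(N3CCNCC3)cc(=O)oc2c1C` gives 2950 nM

These three values come from a functional assay on a cell-free system (plasma, Homo sapiens) for inhibition, with Plasma (Rattus norvegicus) as the target; on this read-out lower numbers stand for stronger inhibition and higher numbers for weaker inhibition. Compound 3 has the lowest number and so shows the strongest inhibition. Compound 2 and compound 1 both sit well above it, beyond the scatter, and within the scatter of each other.

Compound 4 `Cc1c(OCCOc2ccccc2)ccc2c(N3CCNCC3)cc(=O)oc12` has not been measured yet. It turns the propyl of compound 3 into 2-phenoxyethyl, with phenoxy in place of methyl on a saturated chain carbon, two bonds along the chain from an oxygen on an aromatic ring.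

For the measured compounds named here, no two measured compounds differ in only one place, so the data give no direct guide to this change. Compound 3 at 2950 nM is the only reference point with such a chain. A slight move toward stronger inhibition is expected, so the expected 1.5-fold lower number from compound 3 to compound 4 (0.17 log units; within the scatter) is small and may not stand out from the scatter. For compound 4 the estimate in this assay is 2000 nM, within an expected range from 500 nM to 8000 nM.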

Compound 4, half-maximal inhibitory concentration: 9400 nM
Compound 4: middle estimate off by 4.7-fold (0.67 log units), on the low side, and the stated range ends below it.
By their numbers in this assay, from the lowest: compound 3; then compound 4; then compounds 2 and 1 (each within the scatter of the next).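

In this assay, turning propyl into 2-phenoxyethyl gives a 3.2-fold higher number from compound 3 to compound 4 (0.50 log units; beyond the scatter), a modest but real loss of inhibition. For the compounds shown here, this is the first direct sign that this chain responds to what is attached to it, and that phenoxy in place of methyl on a saturated chain carbon, with its added aromatic ring, does not strengthen inhibition here. Nothing measured in the data explains why the step goes this way.

This single step cannot separate the effect of the longer chain from that of the phenoxy ring itself, so a plain butyl or pentyl chain would be needed to tell them apart. On these data alone, whether a chain ending in an amine or a carboxylic acid would fare better or worse than either compound also remains open.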